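Cyano in place of methoxycarbonyl on a fused chromene core

A few compounds are considered here, and "the series" means these few. Any claim that something is new, unique, unknown or untested is made for them only; others in the source may bear on it.

Of the compounds shown here, three have been tested in an ADME assay on MCF-10A cells (Homo sapiens) for cytotoxicity, read by sulforhodamine B assay, with a stated time of 72 h, tested at 30 uM; a higher number here means a stronger effect of the compound at the concentration tested, a lower number a weaker effect. Compound 1 `Cc1ccc(C(=O)/C=C/c2cc(Br)ccc2O)cc1` gives 49.4%, compound 2 `COC(=O)C1=C(N)Oc2ccc(Br)cc2C1CC(=O)c1ccc(Br)cc1` gives 43.2%, and compound 3 `COc1cc(Br)cc2c1OC(N)=C(C#N)C2CC(=O)c1ccccc1` gives 45.9%. Compound 2 therefore sits close to the other two: its number differs from that of compound 3 and from that of compound 1 by amounts within the usual scatter, so nothing separates the three on these readings.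

Compound 4 `N#CC1=C(N)Oc2ccc(Br)cc2C1CC(=O)c1ccc(Br)cc1` has not yet been measured in this assay. It differs from compound 2 in a single place: cyano in place of methoxycarbonyl on a double-bonded ring carbon. Among the measured compounds shown here, no step between measured compounds that share this change is available, so the expectation rests on the three values themselves. Compound 3 already carries a cyano group on its core and gives 45.9%, a number within the scatter of compound 2. On that basis the step expected from compound 2 to compound 4 in this assay is a number 1.8 percentage points higher from compound 2 to compound 4 (within the scatter), none beyond the scatter. Compound 4 is thus estimated to give 45%, with a range from 35% to 55%.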

Compound 4, a percentage reported as activity, at one concentration (the size of the read-out at that concentration, not a potency): 43.6%
Compound 4: the middle estimate sits 1.4 percentage points above what was measured; measured number inside the range.
By their numbers in this assay, from the lowest: compounds 2, 4, 3 and 1 (each within the scatter of the next).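

Among the compounds shown here, the matched pair gives the first direct reading of this change: with everything else held the same, cyano in place of methoxycarbonyl on a double-bonded ring carbon leaves the read-out in this assay within the scatter (a number 0.4 percentage points higher from compound 2 to compound 4 (within the scatter)). Compound 3 could not show this, since it differs from compound 4 in more than one place. At this position, then, the two heavy atoms of cyano and the four of methoxycarbonyl cannot be told apart at the single concentration tested, and nothing available explains this.

On these data alone, whether a carboxylic acid, a primary amide or a longer ester on this carbon would also stay within the scatter remains open. So does whether the same swap would read alike on a core carrying a methoxy group, like that of compound 3.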